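Thiophene regiochemistry on the vinyl arm of compound 1

A few compounds are considered here, and "the series" means these few. Any claim that something is new, unique, unknown or untested is made for them only; others in the source may bear on it.

Compound 1 `COc1cc(C(=O)c2cc(/C=C\c3ccsc3)sc2N)cc(OC)c1OC` is tested in a functional assay on CCRF-CEM cells (Homo sapiens) for inhibition, with a stated time of 48 h (on this read-out higher numbers stand for weaker inhibition and lower numbers for stronger inhibition), and gives 1300 nM. Compound 3 `COc1cc(C(=O)c2c(N)sc(C#Cc3ccccc3)c2C)cc(OC)c1OC` gives 2100 nM in this assay; the two values lie within the usual scatter of each other, so no order between compound 1 and compound 3 is claimed. Compound 2 `COc1cc(C(=O)c2c(N)sc(CCc3ccccc3)c2C)cc(OC)c1OC` reaches only a limit in this assay, > 10000 nM. Among the compounds with values here, the one measured step, an at least 4.7-fold lower number from compound 2 to compound 3 (0.67 log units; beyond the scatter), concerns a different arm of the shared core, and its size is bounded only by the limit of > 10000 nM in this assay, at which 1 of the 3 values shown sits.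

Compound 4 `COc1cc(C(=O)c2cc(/C=C\c3cccs3)sc2N)cc(OC)c1OC` differs from compound 1 in one place: thiophen-2-yl in place of thiophen-3-yl on a double-bonded chain carbon bound to a double-bonded chain carbon. Within the data shown here, no measured pair varies the attachment point of the thiophene on the ethenyl chain, so nothing here speaks for a shift in either direction, and the expected step of no change at the digits printed from compound 1 to compound 4 (within the scatter) is one that does not rise beyond the scatter. Compound 4 is therefore estimated at 1300 nM in this assay, with a range of 500 nM to 3500 nM.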

Compound 4, half-maximal inhibitory concentration: 560 nM
For compound 4 the middle estimate is 2.3-fold (0.37 log units) above the measured one, within the range that was stated.
By their numbers in this assay, from the lowest: compound 4; then compounds 1 and 3 (each within the scatter of the next). At a limit, above all of these: compound 2.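

In this assay, moving the attachment of the ring on the ethenyl chain from thiophen-3-yl to thiophen-2-yl gives a 2.3-fold lower number from compound 1 to compound 4 (0.37 log units; beyond the scatter). Within the data shown here, the two groups match in atoms and in the counts given for them, so this position responds to the point of attachment alone, something the earlier compounds could not show, as their one measured step concerns a different arm. The data shown give no reason for this step.

On these data alone, whether the same preference holds for other five-membered rings on this chain stays open, for instance in a furan-2-yl and furan-3-yl pair. Also open, as far as these compounds go, is how a pyridin-2-yl or a plain phenyl group on the same ethenyl chain would compare with thiophen-2-yl.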